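Swapping the Aryl Group for a Propyl Chain

The source may hold more compounds than are shown below. What is called first, only, known or untested is meant among the compounds shown, and "the series" means these compounds.

Of the compounds shown here, three sharing one core have been measured in a functional assay on MCF7 cells (Homo sapiens) for inhibition, read by MTT assay, with a stated time of 48 h; a higher number here means a weaker inhibitor, a lower number a stronger inhibitor. Compound 1 `Oc1cccc(C(c2c[nH]c3ccc(Br)cc23)c2c[nH]c3ccc(Br)cc23)c1` gives 2800 nM. Compound 2 `COc1ccc(C(c2c[nH]c3ccc(Br)cc23)c2c[nH]c3ccc(Br)cc23)cc1` gives 2300 nM, the lowest of the three numbers. Compound 3 `Clc1ccc(C(c2c[nH]c3ccc(Br)cc23)c2c[nH]c3ccc(Br)cc23)cc1` gives 3500 nM. The steps among them are all small: a 1.2-fold lower number from compound 1 to compound 2 (0.09 log units; within the scatter), a 1.3-fold higher number from compound 1 to compound 3 (0.10 log units; within the scatter) and a 1.5-fold higher number from compound 2 to compound 3 (0.18 log units; within the scatter). Each of these steps exchanges one six-membered aromatic ring of carbon only for another such ring, or one substituent on that ring for another, and none moves the number beyond the scatter.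

Compound 4 `CCCC(c1c[nH]c2ccc(Br)cc12)c1c[nH]c2ccc(Br)cc12` has not yet been measured. It differs from compound 2 in one place: propyl in place of 4-methoxyphenyl on a saturated chain carbon bound to two aromatic carbons. Among the measured compounds shown here, no measured step removes the ring altogether or brings in a chain with no ring, so the three steps above bear on this change only loosely; they show that the core tolerates different groups at this position without a large shift. Compound 4 is therefore expected to give a somewhat higher number, with wide uncertainty, a step of a 2.0-fold higher number from compound 2 to compound 4 (0.29 log units; within the scatter). The estimate for compound 4 in this assay is 4500 nM, between 1500 nM and 14000 nM.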

Compound 4, half-maximal inhibitory concentration: 3600 nM
For compound 4 the middle estimate is 1.3-fold (0.10 log units) above the measured one; measured number inside the range.
By their numbers in this assay, from the lowest: compounds 2, 1, 3 and 4 (each within the scatter of the next).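

Among the compounds shown here, removing the aromatic ring altogether is a change the earlier compounds did not cover, and in this assay it stays small, with a 1.6-fold higher number from compound 2 to compound 4 (0.19 log units; within the scatter), a 1.0-fold higher number from compound 3 to compound 4 (0.01 log units; within the scatter) and a 1.3-fold higher number from compound 1 to compound 4 (0.11 log units; within the scatter) as the three steps to the propyl compound. Among these four compounds, then, a plain propyl chain on the saturated chain carbon bound to two aromatic carbons gives a number that cannot be told apart from those of the three aryl groups, so a ring at this place is not required to stay in this range. Nothing measured here gives a reason for this result.

Going by these compounds, whether a longer chain, a methyl group, or a chain ending in an amine or a carboxylic acid would stay in the same range remains open. On these data alone, all four compounds also share one core, so how this place behaves on a different core is unknown.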